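A few compounds are considered here, and "the series" means these few. Any claim that something is new, unique, unknown or untested is made for them only; others in the source may bear on it.

For the measured compounds named here, compound 1 `Cc1ccccc1C(=O)Nc1sc2c(c1C(N)=O)CCN(C(=S)Nc1ccccc1Cl)C2` is one of two compounds measured so far. Going by the values given here, in a functional assay on HL-60 cells (Homo sapiens) for antiproliferative activity, with a stated time of 24 h (on this read-out higher numbers stand for weaker inhibition and lower numbers for stronger inhibition), compound 1 gives 20900 nM, the lowest of the two numbers, though its only neighbour, compound 2 `CSc1ccccc1C(=O)Nc1sc2c(c1C(N)=O)CCN(C(=S)Nc1ccccc1Cl)C2`, sits within the scatter of it: in this assay compound 2 gives 30500 nM, and the step of a 1.5-fold higher number from compound 1 to compound 2 (0.16 log units; within the scatter) is too small to set the two in order. Compound 3 `Cc1ccccc1C(=O)Nc1sc2c(c1C(N)=O)CCN(C(=S)Nc1ccccc1C(F)(F)F)C2` has not yet been measured. It differs from compound 1 in a single place: trifluoromethyl in place of chloro on an aromatic carbon. Among the compounds with values here, no measured step touches this part of the molecule. Within the data shown here, the only step on record, a 1.5-fold higher number from compound 1 to compound 2 (0.16 log units; within the scatter), changes a different group and was itself within the scatter, so it offers no indication of direction or size for the present change. With nothing in the data pointing either way, the step of a 1.1-fold higher number from compound 1 to compound 3 (0.02 log units; within the scatter) is expected to stay within the scatter. Compound 3 is therefore estimated at 22000 nM in this assay, with a range from 7000 nM to 70000 nM to allow for the absence of any guiding precedent.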

Compound 3, half-maximal inhibitory concentration: 23200 nM
Compound 3: middle estimate off by 1.1-fold (0.02 log units), on the low side; the range from low to high includes it.
By their numbers in this assay, from the lowest: compounds 1, 3 and 2 (each within the scatter of the next).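

For the compounds shown here, the earlier pair changed a different group, so this is the first reading at this position, an aromatic carbon ortho to a large group. In this assay, trifluoromethyl in place of chloro gives a 1.1-fold higher number from compound 1 to compound 3 (0.05 log units; within the scatter), so the two compounds cannot be set in order, even though four heavy atoms enter where one leaves. The 2-chlorophenyl and 2-(trifluoromethyl)phenyl forms thus read alike on this core, and no evidence is at hand on why that is.

The compounds shown leave open whether this tolerance extends beyond these two groups, for instance to an amine, a carboxylic acid, a methoxy group or a longer chain at the same place, or to plain hydrogen there, any of which could read differently. They also leave open whether the same change reads alike when methylsulfanyl takes the place of methyl on the other aromatic ring, as well as whether any group at this position can move the read-out beyond the scatter.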